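A Smaller Halogen on the Pendant Phenyl

The compounds below may be only part of what the source reports. "The series", "measured", "known", "first", "only" and "open" are said of these compounds alone.

Of the compounds shown here, three sharing one core have been tested in an ADME assay on MT4 cells (Homo sapiens) for cytotoxicity, read by MTT assay, with a stated time of 4 days; on this read-out lower numbers stand for higher toxicity in this test and higher numbers for lower toxicity in this test. Compound 1 `Cc1cc(-c2ccc(C#N)cc2)cc(C)c1Nc1ccnc(Nc2ccc(C#N)cc2)n1` gives 2080 nM, compound 2 `Cc1cc(-c2cccc(C(F)(F)F)c2)cc(C)c1Nc1ccnc(Nc2ccc(C#N)cc2)n1` gives 4030 nM, and compound 3 `Cc1cc(-c2ccc(Cl)cc2)cc(C)c1Nc1ccnc(Nc2ccc(C#N)cc2)n1` gives 4190 nM. Compound 2 stands second highest of the three numbers, with compound 3 nearest and compound 1 furthest, both within the scatter. Compound 4 `Cc1cc(-c2cccc(F)c2)cc(C)c1Nc1ccnc(Nc2ccc(C#N)cc2)n1` is not yet measured and differs from compound 2 by fluoro in place of trifluoromethyl on an aromatic carbon. The two steps that swap one of these phenyl groups for another, a 1.9-fold higher number from compound 1 to compound 2 (0.29 log units; within the scatter) and a 1.0-fold higher number from compound 2 to compound 3 (0.02 log units; within the scatter), were within the scatter, as was a 2.0-fold higher number from compound 1 to compound 3 (0.30 log units; within the scatter). The account therefore expects no step beyond the scatter in this assay and estimates compound 4 at 3800 nM, between 1900 nM and 7600 nM. This amounts to an expected 1.1-fold lower number from compound 2 to compound 4 (0.03 log units; within the scatter).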

Compound 4, half-maximal cytotoxic concentration: 4120 nM
Beside the measured number, compound 4's estimate is 1.1-fold (0.04 log units) below it; the measured number falls inside the stated range.
By their numbers in this assay, from the lowest: compounds 1, 2, 4 and 3 (each within the scatter of the next).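

In this assay, going from four heavy atoms to one at this position, meta to a large group, leaves the number within the scatter (a 1.0-fold higher number from compound 2 to compound 4 (0.01 log units; within the scatter)). Compound 4 also stays within the scatter of the two other compounds with a different pendant phenyl group (a 1.0-fold lower number from compound 3 to compound 4 (0.01 log units; within the scatter)) (a 2.0-fold higher number from compound 1 to compound 4 (0.30 log units; within the scatter)). No measurement at hand explains this result.

The compounds shown leave open whether an amine or a carboxylic acid at this position would give a step beyond the scatter.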